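Methyl on the shared core: notes toward compound 4

The compounds below may be only part of what the source reports. "The series", "measured", "known", "first", "only" and "open" are said of these compounds alone.

Compound 1 `CCC(C)Sc1nc(O)cc(Cc2c(F)cccc2F)n1` was run in a functional assay on MT4 cells (Homo sapiens) for cytotoxicity; on this read-out higher numbers stand for lower toxicity in this test and lower numbers for higher toxicity in this test. In this assay compound 1 returns only a limit, > 200000 nM. Compound 2 `CCC(C)Sc1nc(O)c(C)c(Cc2c(F)cccc2F)n1` differs from compound 1 by methyl in place of hydrogen on an aromatic carbon. In this assay compound 2 gives 200000 nM. The step is a number no higher from compound 1 to compound 2 (the limit leaves the size open); the reason its size stays open is the limit of > 200000 nM in this assay, at which 1 of the 3 values shown sits. Compound 3 `CSc1nc(O)cc(C(C)c2c(F)cccc2F)n1` gives 20800 nM in this assay, the lowest of the two numbers given, and its distance from compound 2 is beyond the scatter. The difference between the core of compound 3 and the core of compound 1 is not broken down here.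

Compound 4 `CSc1nc(O)c(C)c(C(C)c2c(F)cccc2F)n1` has not been measured. It differs from compound 3 by methyl in place of hydrogen on an aromatic carbon. This is the same kind of change as that from compound 1 to compound 2, though the surroundings differ: in compound 1 the entering methyl sits ortho to a group of 9 heavy atoms and para to a (sec-butyl)sulfanyl group, in compound 3 it sits ortho to a large group and para to a methylsulfanyl group. Since the measured step leaves its size open, the expectation for compound 4 rests on compound 3 and its value 20800 nM, with a step of about a 1.2-fold higher number from compound 3 to compound 4 (0.08 log units; within the scatter) expected from the one heavy atom entering. Compound 4 is estimated at 25000 nM in this assay, expected between 8000 nM and 80000 nM.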

Compound 4, half-maximal cytotoxic concentration: > 200000 nM
Compound 4: a limit, no number; the forecaster's own chance of this, stated with the estimate: 5%; at least 8.0-fold (0.90 log units) between middle value and limit.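

In this assay the entering methyl on the core of compound 3 gives an at least 9.6-fold higher number from compound 3 to compound 4 (0.98 log units; beyond the scatter), a shift toward lower toxicity in this test on this core. The same change does not carry over as a step of one size from the core of compound 1 to the core of compound 3: the same change on two cores in this assay, a number no higher (the limit leaves the size open) from compound 1 to compound 2 and an at least 9.6-fold higher number (0.98 log units; beyond the scatter) from compound 3 to compound 4, at least 9.6-fold (0.98 log units) apart, beyond the scatter of two such steps Compound 4 returns > 200000 nM, a limit and not a number, which means that the step on the core of compound 3 has no known upper size, the step on the core of compound 1 cannot be read, and the notes show a difference between the two steps but not its true size: the limit of > 200000 nM in this assay, at which 2 of the 4 values shown sit.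

The cores of compound 1 and compound 3 differ in more than one place, and no pair shown separates the methylsulfanyl group from the (sec-butyl)sulfanyl group or isolates the other difference, which leaves open which of these goes with the gap between the steps. Also open, on these data alone, is whether an ethyl group or an amine in place of the entering methyl would give a readable step on either core.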